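The compounds below may be only part of what the source reports. "The series", "measured", "known", "first", "only" and "open" are said of these compounds alone.

Working notes on the series, with an ADME assay on HCT-116 cells (Homo sapiens) for cytotoxicity, read by CellTiter-Glo, with a stated time of 72 h (a higher number here means a weaker inhibitor, a lower number a stronger inhibitor), as the only read-out. Compound 1 (`Cc1cc(C)c(S(=O)(=O)N2CCC(N3CCC(C)CC3)CC2)c(C)c1`) gives > 5000 nM as its entry, and that is a limit, not a number. Compound 2 (`Cc1cc(C)c(S(=O)(=O)N2CCC(c3ccccc3)CC2)c(C)c1`) gives > 5000 nM as its entry, again a limit. Compound 3 (`Cc1ccc(C2CCN(S(=O)(=O)c3c(C)cc(C)cc3C)CC2)cc1`) gives > 5000 nM as its entry, again a limit. Compound 1 therefore has no readable position.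

Compound 4 (`Cc1cc(C)c(S(=O)(=O)N2CCC(N3CCC(CCC#N)CC3)CC2)c(C)c1`) differs from compound 1 by cyanomethyl in place of hydrogen on a saturated chain carbon bound to a saturated ring carbon and, cut one bond further out, the same difference reads methyl to 2-cyanoethyl. Among the compounds with values here, no measured step sits at that place. Two steps replace the whole 4-methylpiperidin-1-yl group that carries the change, namely a step that the two limits leave unreadable from compound 1 to compound 2 and a step that the two limits leave unreadable from compound 1 to compound 3 and neither has a size. Also without a size is a step that the two limits leave unreadable from compound 2 to compound 3 for methyl in place of hydrogen on an aromatic carbon.

No direction can be read from these steps. The expectation rests on compound 1 and on the limit of > 5000 nM in this assay, at which 3 of the 3 values shown sit, so no step beyond the scatter is expected in this assay here. The estimated step is a step that the limit leaves unreadable from compound 1 to compound 4 and a report as a limit is the likely outcome. For compound 4 the estimated value is 6000 nM with an expected range from 2500 nM to 15000 nM in this read-out.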

Compound 4, half-maximal inhibitory concentration: > 5000 nM
Compound 4: no number, only a limit (the forecaster's own chance of this, stated with the estimate: 80%); the middle value lies beyond the limit too.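

In this assay compound 4 gives > 5000 nM, a limit and not a number. No new step can be read between compound 1 and compound 4, as both entries are limits: the limit of > 5000 nM in this assay, at which 4 of the 4 values shown sit.

The compounds shown leave open where any of compounds 1 to 4 truly lies in this assay, and whether methyl to 2-cyanoethyl changes it at all.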